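Methyl to methoxy on the aryl ether of compound 2

This account rests on a few compounds, and the source may have more. Where it says the series, first, only, none or still open, it means among the compounds named here.

Measured so far:
compound 1, `COc1ccc(Oc2c(/C=N\OCc3c(Cl)c(-c4ccc(F)cc4)nn3C)c(C)nn2C)cc1`: 1180 nM
compound 2, `Cc1ccc(Oc2c(/C=N\OCc3c(Cl)c(-c4ccc(Cl)cc4)nn3C)c(C)nn2C)cc1`: 2850 nM

In a functional assay on HCT-116 cells (Homo sapiens) for antiproliferative activity, read by MTT assay, with a stated time of 72 h (a higher number here means a weaker inhibitor, a lower number a stronger inhibitor), compound 2 gives 2850 nM, the higher of the two numbers; compound 1 gives 1180 nM, a gap beyond the scatter. Compound 3, `COc1ccc(Oc2c(/C=N\OCc3c(Cl)c(-c4ccc(Cl)cc4)nn3C)c(C)nn2C)cc1`, differs from compound 2 by methoxy in place of methyl on an aromatic carbon. Going by the values given here, no step of this kind is measured here; compound 1 and compound 3 share the methoxy but differ elsewhere. A modest step toward a lower number is expected for compound 3, a 1.8-fold lower number from compound 2 to compound 3 (0.25 log units; within the scatter), though it may not exceed the scatter. Compound 3 is estimated at 1600 nM, range 700 nM to 3600 nM.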

Compound 3, half-maximal inhibitory concentration: 1260 nM
The estimate for compound 3 lay 1.3-fold (0.10 log units) above the measured number; measured number inside the range.
By their numbers in this assay, from the lowest: compounds 1 and 3 (each within the scatter of the next); then compound 2.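

In this assay, going by these compounds alone, the aromatic carbon of the aryl ether responds to its substituent: 4-methylphenoxy to 4-methoxyphenoxy gives a 2.3-fold lower number from compound 2 to compound 3 (0.35 log units; beyond the scatter), the first matched step at this position. With the methoxy in place, chloro in place of fluoro on an aromatic carbon gives a 1.1-fold higher number from compound 1 to compound 3 (0.03 log units; within the scatter), so the two halogens are not separated here. No supporting data explain the methoxy step.

That step rests on a single pair of compounds. On these data alone, whether an ethoxy, a hydroxy or an amine at the same aromatic carbon would follow it remains open.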